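Hydroxy to methylamino on a saturated ring carbon

This account rests on a few compounds, and the source may have more. Where it says the series, first, only, none or still open, it means among the compounds named here.

In an assay on HEK293T cells for displacement of a labelled ligand from Leucine-rich repeat serine/threonine-protein kinase 2 (Homo sapiens), read by NanoBRET, with a stated time of 2 h (a higher number here means a weaker inhibitor, a lower number a stronger inhibitor), compound 1 `OCCCNc1ncnc2[nH]cc(-c3cccc(Cl)c3)c12` gives 2490 nM, and compound 2 `OC1CCN(c2ncnc3[nH]cc(-c4cccc(Cl)c4)c23)CC1` gives 1340 nM. Among the compounds with values here, compound 2 gives the lowest number so far, yet the step of a 1.9-fold lower number from compound 1 to compound 2 (0.27 log units; within the scatter) lies within the scatter, so neither compound counts as the stronger one. Compound 3 `CNC1CCN(c2ncnc3[nH]cc(-c4cccc(Cl)c4)c23)CC1` differs from compound 2 by methylamino in place of hydroxy on a saturated ring carbon. Within the data shown here, no measured step exchanges these two groups, and the single known step of a 1.9-fold lower number from compound 1 to compound 2 (0.27 log units; within the scatter) concerns a different change, so there is no basis for expecting a shift beyond the scatter. Compound 3 is estimated to give 1000 nM, within a range of 300 nM to 3500 nM. The step of a 1.3-fold lower number from compound 2 to compound 3 (0.13 log units; within the scatter) is expected to stay within the scatter.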

Compound 3, half-maximal inhibitory concentration: 3540 nM
For compound 3 the middle estimate is 3.5-fold (0.55 log units) below the measured one; the measured number lies above the stated range.
By their numbers in this assay, from the lowest: compounds 2, 1 and 3 (each within the scatter of the next, the first and the last beyond it).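

At this saturated ring carbon the group matters: methylamino in place of hydroxy gives a 2.6-fold higher number from compound 2 to compound 3 (0.42 log units; beyond the scatter) in this assay and is a modest change, yet the only step shown that goes beyond the scatter. By contrast, a 1.4-fold higher number from compound 1 to compound 3 (0.15 log units; within the scatter) stays within the scatter, so 4-(methylamino)piperidin-1-yl and (3-hydroxypropyl)amino on the aromatic carbon cannot be told apart here. From the compounds shown here alone, whether a plain amino group or a carboxylic acid on this ring carbon would give a lower or a higher number stays open. Nothing measured here explains why methylamino and hydroxy differ.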